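Dinitrophenyl bis-diazeniumdiolates: growth inhibition notes

A few compounds are considered here, and "the series" means these few. Any claim that something is new, unique, unknown or untested is made for them only; others in the source may bear on it.

Measured so far:
compound 1 `CCOC(=O)N1CCN(/[N+]([O-])=N/Oc2cc(O/N=[N+](\[O-])N(C)C)c([N+](=O)[O-])cc2[N+](=O)[O-])CC1`, 2000 nM in a functional assay on HL-60 cells (Homo sapiens) for antiproliferative activity, read by MTT assay, with a stated time of 72 h; a lower number here means a stronger inhibitor of growth, a higher number a weaker inhibitor of growth;
compound 2 `CCN(CC)C(=O)N1CCN(/[N+]([O-])=N/Oc2cc(O/N=[N+](\[O-])N(C)C)c([N+](=O)[O-])cc2[N+](=O)[O-])CC1`, 4900 nM in this assay.

Going by the values given here, compound 2 gives the higher of the two numbers; the single measured step is a 2.5-fold higher number from compound 1 to compound 2 (0.39 log units; beyond the scatter), a change on a carbonyl carbon.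

Compound 3 `CCOC(=O)N1CCN(/[N+]([O-])=N/Oc2cc(O/N=[N+](\[O-])N3CCN(C(=O)N(CC)CC)CC3)c([N+](=O)[O-])cc2[N+](=O)[O-])CC1` differs from compound 2 by 4-(ethoxycarbonyl)piperazin-1-yl in place of dimethylamino on a double-bonded nitrogen. Among the compounds with values here, no measured step touches that position, so the step from compound 1 to compound 2 does not bear on it directly. With nothing to go on beyond the shared core, compound 3 is expected to stay near compound 2, with no step beyond the scatter: the estimated step is a 1.2-fold lower number from compound 2 to compound 3 (0.09 log units; within the scatter), giving an estimate of 4000 nM for compound 3, within a range of 1400 nM to 12000 nM.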

Compound 3, concentration for total growth inhibition: 3000 nM
Estimate against measurement, compound 3: 1.3-fold (0.12 log units) above, and the stated range covers the measured number.
By their numbers in this assay, from the lowest: compounds 1, 3 and 2 (each within the scatter of the next, the first and the last beyond it).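

On the double-bonded nitrogen whose other neighbours are double-bonded nitrogen and oxygen, this assay gives a 1.6-fold lower number from compound 2 to compound 3 (0.21 log units; within the scatter) for 4-(ethoxycarbonyl)piperazin-1-yl in place of dimethylamino. Going by these compounds alone, this place therefore accepts a group with a six-membered non-aromatic ring and more heavy atoms without a step beyond the scatter, which the carbonyl change between the earlier compounds could not show. No available measurement gives a reason for this result.

Open, going by these compounds, is whether diethylamino, or a piperazine carrying a carboxylic acid instead of the ethyl ester, would also stay within the scatter of compound 2.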